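From methoxy to nitro: what compound 4 may show

The compounds below may be only part of what the source reports. "The series", "measured", "known", "first", "only" and "open" are said of these compounds alone.

Values in a functional assay on HepG2 cells (Homo sapiens) for inhibition, read by MTT assay, with a stated time of 72 h; on this read-out lower numbers stand for stronger inhibition and higher numbers for weaker inhibition:
- compound 1 `COc1ccc(-c2nnc(SCCCN3CCN(c4nc5ccccc5o4)CC3)o2)cc1`: 66100 nM
- compound 2 `O=[N+]([O-])c1ccc(-c2nnc(SCCCN3CCN(c4nc5ccccc5o4)CC3)o2)cc1`: 67200 nM
- compound 3 `COc1ccc(-c2nnc(SCCCN3CCN(c4nc5ccccc5s4)CC3)o2)cc1`: 134000 nM

Compound 3 has the highest of these three numbers, though its gap to compound 2 lies within the scatter. Compound 4 `O=[N+]([O-])c1ccc(-c2nnc(SCCCN3CCN(c4nc5ccccc5s4)CC3)o2)cc1` places nitro in place of methoxy on an aromatic carbon. The same exchange was measured once before, and a 1.0-fold higher number from compound 1 to compound 2 (0.01 log units; within the scatter). The other measured step, a 2.0-fold higher number from compound 1 to compound 3 (0.31 log units; beyond the scatter), exchanges 1,3-benzoxazol-2-yl for 1,3-benzothiazol-2-yl, a change already present in compound 3. One pair is thin evidence, but no step beyond the scatter is expected in this assay. The expected step is a 1.0-fold higher number from compound 3 to compound 4 (0.00 log units; within the scatter). The estimate for compound 4 is 135000 nM, within an expected range of 70000 nM to 260000 nM.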

Compound 4, half-maximal inhibitory concentration: 93300 nM
Compound 4: middle estimate off by 1.4-fold (0.16 log units), on the high side, within the range that was stated.
By their numbers in this assay, from the lowest: compounds 1, 2, 4 and 3 (each within the scatter of the next, the first and the last beyond it).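

In this assay, the change from 4-methoxyphenyl to 4-nitrophenyl now appears on a second core, giving a 1.4-fold lower number from compound 3 to compound 4 (0.16 log units; within the scatter), so neither core shows a step beyond the scatter at this position: the same change on two cores in this assay, a 1.0-fold higher number (0.01 log units; within the scatter) from compound 1 to compound 2 and a 1.4-fold lower number (0.16 log units; within the scatter) from compound 3 to compound 4, 1.5-fold (0.16 log units) apart, within the scatter of two such steps. With nitro in place, 1,3-benzothiazol-2-yl in place of 1,3-benzoxazol-2-yl gives a 1.4-fold higher number from compound 2 to compound 4 (0.14 log units; within the scatter), so the step seen with methoxy, only just beyond the scatter, is not clearly repeated, although the two steps do not differ beyond the scatter: the same change on two cores in this assay, a 2.0-fold higher number (0.31 log units; beyond the scatter) from compound 1 to compound 3 and a 1.4-fold higher number (0.14 log units; within the scatter) from compound 2 to compound 4, 1.5-fold (0.16 log units) apart, within the scatter of two such steps.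

Only methoxy and nitro are shown at this position. On these data alone, what an amine or a carboxylic acid would do there stays open.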